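The source may hold more compounds than are shown below. What is called first, only, known or untested is meant among the compounds shown, and "the series" means these compounds.

Measured compounds:
compound 1, `COc1cccc(NC(=S)NC2CC(C)(C)Oc3ccc(Br)cc32)c1`, 66000 nM
compound 2, `CC(C)NC(=S)NC1CC(C)(C)Oc2ccc(Cl)cc21`, 57000 nM

Two thioureas built on the same bicyclic core have been tested in a functional assay on U-373MG ATCC cells (Homo sapiens) for inhibition, read by MTT assay, with a stated time of 72 h; a higher number here means a weaker inhibitor, a lower number a stronger inhibitor. Compound 1 gives 66000 nM, and compound 2 gives 57000 nM. Of the two numbers, that of compound 1 is the higher one, but the gap to compound 2 lies within the scatter of repeated measurements, so the two compounds cannot be told apart on these data; both are weak inhibitors in this assay .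

Compound 3, `CC1(C)CC(NC(=S)Nc2ccccc2Cl)c2cc(Br)ccc2O1`, has not yet been measured in this assay . It differs from compound 1 in one place: 2-chlorophenyl in place of 3-methoxyphenyl on an amide-type nitrogen. Going by the values given here, no measured pair shows what a change of this kind does on this core, so nothing in the data points in either direction. The expectation for compound 3 is therefore that the step of a 1.1-fold lower number from compound 1 to compound 3 (0.04 log units; within the scatter) stays within the scatter, with no change beyond it. On that basis compound 3 is estimated to give 60000 nM in this assay , with a range from 25000 nM to 150000 nM.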

Compound 3, half-maximal inhibitory concentration: 34000 nM
Estimate against measurement, compound 3: 1.8-fold (0.25 log units) above; the measured number falls inside the stated range.
By their numbers in this assay, from the lowest: compounds 3, 2 and 1 (each within the scatter of the next).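

In this assay, going by these compounds alone, 2-chlorophenyl in place of 3-methoxyphenyl on an amide-type nitrogen whose other neighbour is the thiocarbonyl carbon gives a 1.9-fold lower number from compound 1 to compound 3 (0.29 log units; within the scatter), the first step on this core that can be read between two compounds differing in one place. The exchange removes the hydrogen-bond acceptor of 3-methoxyphenyl and brings in a chlorine, yet the step stays within the scatter, so this one pair does not separate the two substituted phenyl groups at this position. The data offer no measurement that would explain the size of this step.

Within the data shown here, the pair covers only two substituted phenyl groups, so it remains open whether an amine, a carboxylic acid or a longer alkyl chain on this nitrogen would carry the number beyond the scatter, and a single step cannot show whether 2-chlorophenyl would give a similar result on the core of compound 2. All three compounds are thioureas, which also leaves open what a urea carbonyl in place of the thiocarbonyl would do in this assay.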